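A Bromine and Methyl Swap on the Amide Ring

This account rests on a few compounds, and the source may have more. Where it says the series, first, only, none or still open, it means among the compounds named here.

Compound 1 `COc1ccc(-c2nnsc2SCC(=O)Nc2ccccc2Cl)cc1` belongs to a small set of three related molecules examined in an ADME assay on MT4 cells (Homo sapiens) for cytotoxicity (a higher number here means that more compound is tolerated, a lower number that less compound is tolerated), for how much of each a human cell line can tolerate. For compound 1 the outcome is only a limit of the assay: compound 1 gives > 318000 nM, so no exact number is known. Two relatives share the same core. Compound 2 `O=C(CSc1snnc1-c1ccc(Cl)cc1Cl)Nc1ccccc1Br` likewise reaches a limit of the assay, giving >= 146000 nM. Compound 3 `O=C(CSc1snnc1-c1ccc(F)cc1F)Nc1ccccc1Br` gives a measured value of 144000 nM. For the measured compounds named here, the one step with a number, an at least 1.0-fold lower number from compound 2 to compound 3 (0.00 log units; that floor lies within the scatter), concerns a change on an aromatic carbon and sits well within the scatter.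

Compound 4 `COc1ccc(-c2nnsc2SCC(=O)Nc2ccc(C)cc2Br)cc1` differs from compound 1 at the other end of the molecule: 2-bromo-4-methylphenyl in place of 2-chlorophenyl on an amide-type nitrogen. Going by the values given here, no measured step tests a change at this position, and the step from compound 2 to compound 3 touches a different part of the core. With all three known values sitting at or near the upper reach of this assay, including the limit of compound 1 marked by the limit of > 318000 nM in this assay, at which 1 of the 3 values shown sits, the expectation is that compound 4 stays equally well tolerated, with no step beyond the scatter, so the expected step is an at least 1.4-fold lower number from compound 1 to compound 4 (0.16 log units; that floor lies within the scatter). Compound 4 is therefore estimated at 220000 nM, with a likely range from 90000 nM to 500000 nM.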

Compound 4, half-maximal cytotoxic concentration: 249000 nM
For compound 4 the middle estimate is 1.1-fold (0.05 log units) below the measured one, within the range that was stated.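

In this assay, putting 2-bromo-4-methylphenyl in place of 2-chlorophenyl on an amide-type nitrogen gives an at least 1.2-fold lower number from compound 1 to compound 4 (0.10 log units; that floor lies within the scatter). This figure is only a floor, and the true step could be larger, because the value of compound 1 is a limit of the assay and not a number: the limit of > 318000 nM in this assay, at which 1 of the 4 values shown sits. Even so, compound 4 gives an exact value of 249000 nM, so this position now has a real number on the changed side of the step, and the swap gives no sign of a step beyond the scatter.

The bromine and the methyl enter together, so the compounds shown cannot separate what each contributes, and an exact value for compound 1 would be needed to fix the size of the step. They also leave open how a very different group on this ring, such as an amine or a carboxylic acid, would behave in this assay.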